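The source may report more compounds than this note shows. Statements on the series, on what has been measured and on what is new or still open speak of the compounds shown alone.

Of the compounds shown here, two built on a shared core have been measured in an assay on isolated protein (strain Sprague-Dawley) for inhibition of Amine oxidase [flavin-containing] B (Rattus norvegicus), read by spectrophotometry, with a stated time of 5 min; a lower number here means a stronger inhibitor, a higher number a weaker inhibitor. Compound 1 `CN(C)C(=O)COc1cc(=O)oc2cc(OCc3cccc(Cl)c3)ccc12` gives 501 nM, the higher of the two numbers. Compound 2 `O=c1cc(CO)c2ccc(OCc3cccc(Br)c3)cc2o1` gives 14.1 nM, and that gap lies beyond the usual scatter, so compound 1 is the weaker inhibitor of the pair. Compound 3 `N#Cc1cc(=O)oc2cc(OCc3cccc(Cl)c3)ccc12` has not yet been measured; it differs from compound 1 by cyano in place of (dimethylcarbamoyl)methoxy on an aromatic carbon. A step toward a stronger inhibitor is expected, as a 10-fold lower number from compound 1 to compound 3 (1.00 log units; beyond the scatter), because compound 2 gives 14.1 nM with its own smaller group. Compound 3 is expected at 50 nM, within a range from 10 nM to 250 nM.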

Compound 3, half-maximal inhibitory concentration: 102 nM
Compound 3: middle estimate off by 2.0-fold (0.31 log units), on the low side, and the stated range covers the measured number.
By their numbers in this assay, from the lowest: compound 2; then compound 3; then compound 1.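

For the compounds shown here, on the aromatic carbon opposite the ring oxygen, cyano in place of (dimethylcarbamoyl)methoxy gives a 4.9-fold lower number from compound 1 to compound 3 (0.69 log units; beyond the scatter) in this assay, a modest step and the first comparison in which only this position changes. In this pair, the larger group and its amide are therefore not needed for inhibition. No measurement shown explains the step. From the compounds shown here alone, it remains open how a primary amine or a carboxylic acid would compare on this carbon, and whether a longer chain ending in cyano would keep the lower number.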